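The source may hold more compounds than are shown below. What is called first, only, known or untested is meant among the compounds shown, and "the series" means these compounds.

Compound 3 `COc1ccc(-c2nnc(SCC(=O)NNC(=O)c3ccccc3O)n2-c2ccccc2)cc1OC` was tested in an ADME assay on MDA-MB-435 cells (Homo sapiens) for cytotoxicity; a lower number here means that less compound is tolerated, a higher number that more compound is tolerated. In this assay compound 3 gives > 20000 nM, which is a limit of the assay and not a number. Two related compounds were measured alongside it. Compound 1 `Cc1ccc(-n2c(SCC(=O)NNC(=O)c3ccccc3O)nnc2-c2ccccc2O)cc1` gives > 20000 nM, again a limit rather than a number. Compound 2 `O=C(CSc1nnc(-c2ccc(Cl)cc2)n1-c1ccccc1)NNC(=O)c1ccccc1O` gives > 20000 nM, also a limit. All three values therefore sit at the limit of > 20000 nM in this assay, at which 3 of the 3 values shown sit, so compound 3 stands level with the other two and nothing sets it apart. Among the compounds with values here, the one single-point comparison among them, a step that the two limits leave unreadable from compound 2 to compound 3, cannot be read, since both of its ends are limits.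

Compound 4 `Cc1cc(C)nc(SCc2nnc(SCC(=O)NNC(=O)c3ccccc3O)n2-c2ccccc2)n1` differs from compound 3 by ((4,6-dimethylpyrimidin-2-yl)sulfanyl)methyl in place of 3,4-dimethoxyphenyl on an aromatic carbon. Within the data shown here, no measured step bears on this change, as the only comparison available is unreadable. Among the measured compounds shown here, since every value so far stops at the same limit, no step beyond the scatter is expected for compound 4, and its tolerated concentration is expected to remain at that limit, which corresponds to an expected step that the limit leaves unreadable from compound 3 to compound 4. Compound 4 is estimated at 30000 nM, with a range from 15000 nM to 80000 nM, and most likely the assay will again report only a limit.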

Compound 4, half-maximal cytotoxic concentration: > 20000 nM
Compound 4: a limit, no number; the forecaster's own chance of this, stated with the estimate: 85%; the middle value lies beyond the limit too.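

In this assay compound 4 gives > 20000 nM, a limit and not a number. Its steps from compound 3 and from compound 2 cannot be read, since both ends of each step are limits: the limit of > 20000 nM in this assay, at which 4 of the 4 values shown sit.

The compounds shown leave open what concentration of each is tolerated, and whether changing the group on the shared core alters it at all.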